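Pyrrolidinol versus acetamidoethylamine side chains: compound 3 to compound 4

This account rests on a few compounds, and the source may have more. Where it says the series, first, only, none or still open, it means among the compounds named here.

Values in a functional assay on B16-F10 cells (Mus musculus) for antiproliferative activity, read by CCK-8 assay, with a stated time of 48 h (a higher number here means a weaker inhibitor, a lower number a stronger inhibitor), for the series so far:
- compound 1 (`COc1ccc(/C=C\c2cc(OC)c(OC)c(OC)c2)cc1OCc1ccc(CNCCO)cc1`) gives 6600 nM as a number
- compound 2 (`COc1ccc(/C=C\c2cc(OC)c(OC)c(OC)c2)cc1OCc1ccc(CN2CC[C@H](O)C2)cc1`) gives > 10000 nM as a limit of the assay, not a number
- compound 3 (`COc1ccc(/C=C\c2cc(OC)c(OC)c(OC)c2)cc1OCc1ccc(CNCCNC(C)=O)cc1`) gives 2500 nM as a number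

Compound 3 holds the lower of the two numbers, with a 2.6-fold lower number from compound 1 to compound 3 (0.42 log units; beyond the scatter) as the step that separates them. Compound 4 (`COc1ccc(/C=C\c2cc(OC)c(OC)c(OC)c2)cc1OCc1ccc(CN2CC[C@@H](O)C2)cc1`) differs from compound 3 by the change 3-hydroxypyrrolidin-1-yl in place of (2-acetamidoethyl)amino on a saturated chain carbon bound to an aromatic carbon in which 3-hydroxypyrrolidin-1-yl takes the place of (2-acetamidoethyl)amino. Compound 2 carries the same group, with the opposite configuration at its defined stereocentre. Among the compounds with values here, the closest guide is therefore an at least 4.0-fold lower number from compound 2 to compound 3 (0.60 log units; beyond the scatter) taken in reverse, and no measurement yet shows what the configuration does. The step of an at least 1.5-fold higher number from compound 1 to compound 2 (0.18 log units; that floor lies within the scatter) adds only a floor. A higher number of similar size is expected in this assay and a reported limit is quite possible. The expected step is a 3.6-fold higher number from compound 3 to compound 4 (0.56 log units; beyond the scatter) on this reasoning. Compound 4 is estimated at 9000 nM with an expected range of 4000 nM to 20000 nM in this assay.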

Compound 4, half-maximal inhibitory concentration: > 10000 nM
Compound 4: no number, only a limit; the forecaster's own chance of this, stated with the estimate: 50%; middle value at least 1.1-fold (0.04 log units) away from the limit.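

In this assay, the 3-hydroxypyrrolidin-1-yl group with the opposite configuration also falls short of the (2-acetamidoethyl)amino side chain, with an at least 4.0-fold higher number from compound 3 to compound 4 (0.60 log units; beyond the scatter), so the shortfall seen with compound 2 is not confined to one drawn configuration. Against the (2-hydroxyethyl)amino side chain, the same ring gives only a floor, an at least 1.5-fold higher number from compound 1 to compound 4 (0.18 log units; that floor lies within the scatter), which does not separate the two side chains. The step from compound 2 to compound 4 cannot be read, because both values are limits of the assay: the limit of > 10000 nM in this assay, at which 2 of the 4 values shown sit.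

The compounds shown leave open whether the ring or its hydroxy group accounts for the limit values, which an unsubstituted pyrrolidin-1-yl group would address. They also leave open whether the acetamido group of compound 3 could be matched by a urea or a carboxylic acid at the end of the same chain.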